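The source may hold more compounds than are shown below. What is called first, only, known or untested is meant among the compounds shown, and "the series" means these compounds.

Compound 1 `NC(=O)N1CCN(C(=S)SCc2cn(Cc3ccccc3F)nn2)CC1`, compound 2 `NC(=O)N1CCN(C(=S)SCc2cn(Cc3ccc(Cl)cc3)nn2)CC1` and compound 3 `Cc1ccc(Cn2cc(CSC(=S)N3CCN(C(N)=O)CC3)nn2)cc1` share one core and differ only at the benzyl group. In a functional assay on MCF7 cells (Homo sapiens) for cytotoxicity, read by MTT assay, with a stated time of 72 h (on this read-out lower numbers stand for stronger inhibition and higher numbers for weaker inhibition), compound 1 gives > 128000 nM, a limit of the assay rather than a number. Compound 2 gives > 128000 nM in this assay, again a limit. Compound 3 stands at > 128000 nM in this assay, also a limit, so it cannot be placed relative to the others; the limit of > 128000 nM in this assay, at which 3 of the 3 values shown sit, covers all three. The steps a step that the two limits leave unreadable from compound 1 to compound 2, a step that the two limits leave unreadable from compound 1 to compound 3 and a step that the two limits leave unreadable from compound 2 to compound 3 are thus of unreadable size. Compound 4 `COc1ccc(Cn2cc(CSC(=S)N3CCN(C(N)=O)CC3)nn2)cc1` differs from compound 3 by methoxy in place of methyl on an aromatic carbon. Only a step that the two limits leave unreadable from compound 2 to compound 3 bears on this change and it was unreadable, so for compound 4 the step of a number no higher from compound 3 to compound 4 (the limit leaves the size open) in this assay is expected to be none beyond the scatter. Compound 4 is estimated at 128000 nM, within 50000 nM to 400000 nM, most likely reported as a limit.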

Compound 4, half-maximal inhibitory concentration: > 128000 nM
Compound 4: no number, only a limit; the forecaster's own chance of this, stated with the estimate: 85%; the middle value lies on the limit itself.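

Among the compounds shown here, compound 4 also reads only as a limit in this assay, so no step linking it to compound 1, compound 2 or compound 3 can be read: the limit of > 128000 nM in this assay, at which 4 of the 4 values shown sit. As far as these compounds go, whether any benzyl group on the shared core gives a measurable value stays open.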